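Moving the methyl group: from compound 1 to compound 4

The source may report more compounds than this note shows. Statements on the series, on what has been measured and on what is new or still open speak of the compounds shown alone.

In a functional assay on K562 cells (Homo sapiens) for cytotoxicity, in the presence of a further agent that is not named here (on this read-out higher numbers stand for weaker inhibition and lower numbers for stronger inhibition), compound 1 (`Cc1ccccc1-c1cc(-c2ccc(Cl)o2)cc(-c2ccsc2)n1`) gives 18400 nM. Compound 2 (`Clc1ccc(-c2cc(-c3cccs3)nc(-c3ccccc3Cl)c2)o1`) gives 17200 nM, and compound 3 (`Clc1cccc(-c2cc(-c3ccc(Cl)o3)cc(-c3cccs3)n2)c1`) gives 19800 nM. Compound 1 therefore stands within the scatter of both of the other measured compounds, and the three numbers show no order.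

Compound 4 (`Cc1ccc(-c2cc(-c3ccc(Cl)o3)cc(-c3ccsc3)n2)cc1`) has the same atoms as compound 1, joined differently: 4-methylphenyl in place of 2-methylphenyl on an aromatic carbon.

Among the compounds with values here, the one measured step that bears on this change is a 1.2-fold higher number from compound 2 to compound 3 (0.06 log units; within the scatter), with 3-chlorophenyl in place of 2-chlorophenyl. Within the data shown here, that step involves a different group and a different position, and no measured compound carries the 4-methylphenyl group, so the support is indirect. Nothing in the data points to a shift in either direction in this assay.

The expected step is a 1.0-fold higher number from compound 1 to compound 4 (0.01 log units; within the scatter), an estimate that stays within the scatter.

For compound 4 the estimated value is 19000 nM, with an expected range of 11000 nM to 32000 nM.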

Compound 4, half-maximal inhibitory concentration: 19900 nM
The estimate for compound 4 lay 1.0-fold (0.02 log units) below the measured number, within the range that was stated.
By their numbers in this assay, from the lowest: compounds 2, 1, 3 and 4 (each within the scatter of the next).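

Moving the methyl group from 2-methylphenyl to 4-methylphenyl, at the place next to the ring nitrogen, gives a 1.1-fold higher number from compound 1 to compound 4 (0.03 log units; within the scatter) in this assay, so this change of position leaves the read-out unmoved. Within the data shown here, compound 4 supplies the first direct pair for a methyl group here; alongside a 1.2-fold higher number from compound 2 to compound 3 (0.06 log units; within the scatter) for the chlorophenyl pair, it gives a second position change that stays within the scatter. No supporting measurement is available to explain this flat result.

The compounds shown carry only methylphenyl and chlorophenyl groups at this place, so they do not show how far the read-out can move there. On these data alone, whether a carboxylic acid or an aminomethyl group on this phenyl ring would give a step beyond the scatter remains open.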